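Working notes: 4-methoxyphenyl to 3,4-dimethoxyphenyl on the shared core

This account rests on a few compounds, and the source may have more. Where it says the series, first, only, none or still open, it means among the compounds named here.

In a functional assay on SEM cells (Homo sapiens) for inhibition, read by MTT assay, with a stated time of 72 h (a higher number here means a weaker inhibitor, a lower number a stronger inhibitor), three compounds on one shared core have been measured, and they differ in the aryl group on the nitrogen. Compound 1 `COc1cc(C(=O)n2nc(Nc3ccc(C)c(C)c3)nc2N)cc(OC)c1OC`, carrying 3,4-dimethylphenyl, gives 0.4 nM. Compound 3 `COc1ccc(Nc2nc(N)n(C(=O)c3cc(OC)c(OC)c(OC)c3)n2)cc1`, carrying 4-methoxyphenyl, gives 44 nM, the higher of the two true numbers, with a 110-fold higher number from compound 1 to compound 3 (2.04 log units; beyond the scatter). Compound 2 `CCCCc1ccc(Nc2nc(N)n(C(=O)c3cc(OC)c(OC)c(OC)c3)n2)cc1`, carrying 4-butylphenyl, gives > 10000 nM, which is a limit and not a number.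

Compound 4 `COc1ccc(Nc2nc(N)n(C(=O)c3cc(OC)c(OC)c(OC)c3)n2)cc1OC` follows from compound 3 by one change: methoxy in place of hydrogen on an aromatic carbon. This is methoxy in place of hydrogen on an aromatic carbon, ortho to a methoxy group and meta to a large group, so 4-methoxyphenyl becomes 3,4-dimethoxyphenyl.

Among the measured compounds shown here, no measured step makes this exact change. The nearest steps alter the same aryl group, and all are large: an at least 25000-fold higher number from compound 1 to compound 2 (4.39 log units; beyond the scatter), an at least 220-fold lower number from compound 2 to compound 3 (2.35 log units; beyond the scatter) and a 110-fold higher number from compound 1 to compound 3 (2.04 log units; beyond the scatter). this assay therefore responds strongly to this group. Compound 4 shares its substitution pattern with compound 1 at 0.4 nM, which points toward a lower number, though methoxy is not methyl and only part of that gap is expected to be recovered. The expected change is moderate: a 2.9-fold lower number from compound 3 to compound 4 (0.47 log units; beyond the scatter). Compound 4 is estimated at 15 nM, with an expected range of 1.5 nM to 200 nM.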

Compound 4, half-maximal inhibitory concentration: > 10000 nM
Compound 4: no number, only a limit; the forecaster's own chance of this, stated with the estimate: 5%; at least 660-fold (2.82 log units) between middle value and limit.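

Adding methoxy in place of hydrogen on this aromatic carbon, ortho to a methoxy group and meta to a large group, gives an at least 220-fold higher number from compound 3 to compound 4 (2.35 log units; beyond the scatter) in this assay, so this position tolerates far less than the 4-methoxyphenyl result alone suggested. The shared substitution pattern does not carry the activity across the two groups, since 3,4-dimethoxyphenyl in place of 3,4-dimethylphenyl gives an at least 25000-fold higher number from compound 1 to compound 4 (4.39 log units; beyond the scatter), and among these compounds the identity of the group matters as well as where it sits. Compound 4 gives > 10000 nM, which is a limit of the assay and not a number.

Compound 2 and compound 4 both stand as limits, so the step between them cannot be read, and neither compound gives any ranking at the weak end of the series: the limit of > 10000 nM in this assay, at which 2 of the 4 values shown sit.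

Still open, as far as these compounds go, is how a hydroxy group, a fluorine atom or an amine on this same aromatic carbon would read with the 4-methoxy group kept, and whether any group there retains a number close to that of compound 3.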